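A few compounds are considered here, and "the series" means these few. Any claim that something is new, unique, unknown or untested is made for them only; others in the source may bear on it.

Two measured compounds frame this account. Compound 1 `COc1cc2c(Nc3nc4ccc(C(=O)Nc5c(C)cc(C)cc5C)cc4s3)ncnc2cc1OCCCN1CCC(C)CC1` gives 6900 nM in a functional assay on HCT-116 cells (Homo sapiens) for cytotoxicity, read by WST assay, with a stated time of 72 h; on this read-out higher numbers stand for weaker inhibition and lower numbers for stronger inhibition. Compound 2 `CCN(CC)CCCOc1cc2ncnc(Nc3nc4ccc(C(=O)Nc5c(C)cccc5Cl)cc4s3)c2cc1OC` gives 13200 nM in this assay; the gap between compound 2 and compound 1 lies within the usual scatter, so the two numbers cannot be told apart with confidence.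

Compound 3 `COc1cc2c(Nc3nc4ccc(C(=O)Nc5c(C)cccc5Cl)cc4s3)ncnc2cc1OCCCN1CCC(C)CC1` is reached from compound 2 by one change, (4-methylpiperidin-1-yl in place of diethylamino on a saturated chain carbon, three bonds along the chain from an oxygen on an aromatic ring), with the rest of the molecule kept the same. Among the compounds with values here, no measured pair differs in this place alone, so nothing in the data fixes the size of this step in this assay. Compound 1 carries the same 4-methylpiperidin-1-yl and gives 6900 nM, but it also differs from compound 2 elsewhere, so that comparison is not clean. The step from compound 2 to compound 3 is therefore expected to stay within the scatter, estimated as a 1.5-fold lower number from compound 2 to compound 3 (0.17 log units; within the scatter). Compound 3 is expected to give about 9000 nM, with a range from 3500 nM to 25000 nM.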

Compound 3, half-maximal inhibitory concentration: 9100 nM
Compound 3: middle estimate off by 1.0-fold (0.00 log units), on the low side; measured number inside the range.
By their numbers in this assay, from the lowest: compounds 1, 3 and 2 (each within the scatter of the next).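

In this assay, the swap of diethylamino for 4-methylpiperidin-1-yl on the saturated chain carbon, three bonds along the chain from an oxygen on an aromatic ring, is a 1.5-fold lower number from compound 2 to compound 3 (0.16 log units; within the scatter) and so cannot be told from repeat measurement. Within the data shown here, this gives the first clean reading at this position: the larger ring-bearing amine and the open-chain amine cannot be separated here. The second clean pair, with 2-chloro-6-methylphenyl in place of 2,4,6-trimethylphenyl on an amide-type nitrogen, is a 1.3-fold higher number from compound 1 to compound 3 (0.12 log units; within the scatter) and is also unresolved, and nothing available explains either step.

The compounds shown leave open whether a morpholine or a 4-methylpiperazine at the end of the chain, or a chain shorter than the propyl, would move the number beyond the scatter. They also leave open whether an unsubstituted phenyl on the amide-type nitrogen would do so.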